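Fluoro Analogue of a Piperazinyl Pyrazole Binding Series

The source may hold more compounds than are shown below. What is called first, only, known or untested is meant among the compounds shown, and "the series" means these compounds.

Compound 1 `COc1cccc(-c2n[nH]cc2N2CCNCC2)c1` gives only the assay limit > 10000 nM in an assay on isolated protein for binding affinity to 5-hydroxytryptamine receptor 4 (Homo sapiens); a higher number here means a weaker inhibitor, a lower number a stronger inhibitor.
Compound 2 `c1ccc(-c2n[nH]cc2N2CCNCC2)cc1` gives only the limit > 10000 nM in this assay.
Compound 3 `Clc1ccc(-c2n[nH]cc2N2CCNCC2)cc1` gives only the limit > 10000 nM in this assay.

Compound 2 therefore stands at the limit of > 10000 nM in this assay, at which 3 of the 3 values shown sit, with no number of its own. Compound 4 `Fc1cccc(-c2n[nH]cc2N2CCNCC2)c1` differs from compound 2 by fluoro in place of hydrogen on an aromatic carbon. The two measured changes on the same ring, a step that the two limits leave unreadable from compound 1 to compound 2 and a step that the two limits leave unreadable from compound 2 to compound 3, are both unreadable, so they give no direction for a ring substituent. No readable step is expected, and compound 4 is expected to give a step that the limit leaves unreadable from compound 2 to compound 4 in this assay. The estimate for compound 4 is 20000 nM, in the range 5000 nM to 100000 nM, most likely reported again only as a limit.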

Compound 4, inhibition constant: > 10000 nM
Compound 4: only a limit was reported; the forecaster's own chance of this, stated with the estimate: 85%; the middle value lies beyond the limit too.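

Going by these compounds alone, compound 4, like compound 1 and compound 2, gives only a limit, so no step to compound 4 can be read. Going by these compounds, whether any ring substituent on the shared core gives a measurable affinity in this assay stays open.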